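The compounds below may be only part of what the source reports. "The series", "measured", "known", "first", "only" and "open" are said of these compounds alone.

In a functional assay on 786-0 cells (Homo sapiens) for antiproliferative activity, read by sulforhodamine B assay, with a stated time of 48 h (a higher number here means a weaker inhibitor, a lower number a stronger inhibitor), compound 1 `O=C(NCCCNc1cc(-c2cn(-c3ccccc3)nc2-c2cccc(O)c2)ccn1)Nc1ccc(F)cc1` gives 860 nM and compound 2 `O=C(NCCCNc1cc(-c2cn(-c3ccccc3)nc2-c2cccc(O)c2)ccn1)Nc1cccc(C(F)(F)F)c1` gives 1070 nM which places the two within the scatter of each other, so compound 1 holds no clear rank. Compound 3 `COc1cccc(-c2nn(-c3ccccc3)cc2-c2ccnc(NCCCNC(=O)Nc3ccc(F)cc3)c2)c1` differs from compound 1 in one place: methyl in place of hydrogen on an oxygen on an aromatic ring turning 3-hydroxyphenyl into 3-methoxyphenyl. Among the measured compounds shown here, the one measured step of a 1.2-fold higher number from compound 1 to compound 2 (0.09 log units; within the scatter) concerns a different place, an amide-type nitrogen, so no measurement tests the hydroxy group directly. The expected change is a 1.4-fold higher number from compound 1 to compound 3 (0.14 log units; within the scatter) with nothing beyond the scatter anticipated on this evidence. Compound 3 is estimated at 1200 nM with 400 nM to 3500 nM as its expected range.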

Compound 3, half-maximal inhibitory concentration: 9340 nM
For compound 3 the middle estimate is 7.8-fold (0.89 log units) below the measured one; the measured number lies above the stated range.
By their numbers in this assay, from the lowest: compounds 1 and 2 (each within the scatter of the next); then compound 3.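

In this assay, turning 3-hydroxyphenyl into 3-methoxyphenyl gives an 11-fold higher number from compound 1 to compound 3 (1.04 log units; beyond the scatter), so this position responds strongly to one added methyl. The earlier change on the amide-type nitrogen, a 1.2-fold higher number from compound 1 to compound 2 (0.09 log units; within the scatter), showed no such sensitivity. Nothing measured here gives a reason for this loss of activity.

As far as these compounds go, it remains open whether the free hydroxy group itself is what matters. An amine in place of the hydroxy, or an ethoxy group in place of the methoxy, might stay close to compound 1 or fall as far as compound 3.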